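Methoxy for methyl in two arms of one series

This account rests on a few compounds, and the source may have more. Where it says the series, first, only, none or still open, it means among the compounds named here.

Compound 1 `COc1ccc(/N=C\c2cn(-c3ccc(Cl)cc3)nc2-c2ccc(C)cc2)cc1` and compound 2 `COc1ccc(/N=C\c2cn(-c3ccc(Cl)cc3)nc2-c2ccc(OC)cc2)cc1` share a core and are both measured in a functional assay on the whole organism (strain Wistar albino) for inhibition, with Rattus norvegicus as the target, read by paw edema, with stated times of 1 h and 2 h, at a dose of 0.32 mmol/kg by the intraperitoneal route; on this read-out lower numbers stand for less inhibition and higher numbers for more inhibition at the one dose given (going by the name of the read-out). Compound 1 gives 62%; compound 2 gives 69.2%. The change between them is methoxy in place of methyl on an aromatic carbon and the step it makes is a number 7.2 percentage points higher from compound 1 to compound 2 (within the scatter).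

Compound 3 `Cc1ccc(-c2nn(-c3ccc(Cl)cc3)cc2/C=C\C(=O)c2ccc(Cl)cc2)cc1` has a different core; the difference between the two cores is not broken down here. In this assay, within the data shown here, compound 3 gives 49.2%, the lowest of the three numbers measured so far, and its gap to compound 1 as well as to compound 2 lies beyond the scatter.

Compound 4 `COc1ccc(-c2nn(-c3ccc(Cl)cc3)cc2/C=C\C(=O)c2ccc(Cl)cc2)cc1` is not yet measured. It differs from compound 3 by methoxy in place of methyl on an aromatic carbon, the same change, at the same kind of place, as that from compound 1 to compound 2. Among the measured compounds shown here, on that single earlier step, which stayed within the scatter, the step to compound 4 is expected to be about a number 6.8 percentage points higher from compound 3 to compound 4 (within the scatter), because a number 7.2 percentage points higher from compound 1 to compound 2 (within the scatter) is the only guide available. Compound 4 is therefore estimated at 56% in this assay, between 45% and 67%.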

Compound 4, a percentage reported as inhibition, in the whole organism at one dose (the size of the read-out at that dose, not a potency): 53.7%
The estimate for compound 4 lay 2.3 percentage points above the measured number, and the stated range covers the measured number.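

In this assay, going from 4-methylphenyl to 4-methoxyphenyl on the core of compound 3 gives a number 4.5 percentage points higher from compound 3 to compound 4 (within the scatter), and the two steps for this change on the two cores cannot be told apart: the same change on two cores in this assay, a number 7.2 percentage points higher (within the scatter) from compound 1 to compound 2 and a number 4.5 percentage points higher (within the scatter) from compound 3 to compound 4, 2.7 percentage points apart, within the scatter of two such steps This shows that the swap gives a step within the scatter on both cores, so on this evidence the outcome carries from one core to the other as no distinguishable shift in the read-out. It does not show that a real gain carries over, since neither step can be separated from repeat measurement, and the comparison rests on one pair per core, at the one dose given.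

The compounds shown leave open how an amine, a carboxylic acid, a hydroxyl or a longer chain such as ethoxy would behave at this same place on the ring. They also leave open whether any such group would give steps beyond the scatter, and whether those steps would match on the two cores.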